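This account rests on a few compounds, and the source may have more. Where it says the series, first, only, none or still open, it means among the compounds named here.

Series notes. Three analogues on a shared core have been measured in an assay on microsomes from liver for inhibition of 3-hydroxy-3-methylglutaryl-coenzyme A reductase (Rattus norvegicus); a lower number here means a stronger inhibitor, a higher number a weaker inhibitor. Compound 1 `COc1cccc(-c2nc(C(F)(F)F)n(CC[C@@H](O)C[C@@H](O)CC(=O)O)c2-c2ccc(F)cc2)c1` gives 20 nM. Compound 2 `O=C(O)C[C@H](O)C[C@H](O)CCn1c(C(F)(F)F)nc(-c2ccc(F)cc2)c1-c1ccc(F)cc1` gives 38 nM. Compound 3 `Cc1ccc(-c2nc(C(F)(F)F)n(CC[C@@H](O)C[C@@H](O)CC(=O)O)c2-c2ccc(F)cc2)cc1` gives 43 nM. On these numbers compound 2 cannot be separated from either neighbour: the step of a 1.9-fold higher number from compound 1 to compound 2 (0.28 log units; within the scatter) and the step of a 1.1-fold higher number from compound 2 to compound 3 (0.05 log units; within the scatter) both stay inside the scatter. Within the data shown here, only the step of a 2.2-fold higher number from compound 1 to compound 3 (0.33 log units; beyond the scatter) reaches just past it.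

Compound 4 `Cc1cc(-c2nc(C(F)(F)F)n(CC[C@@H](O)C[C@@H](O)CC(=O)O)c2-c2ccc(F)cc2)cc(C)c1F` is not yet measured. It differs from compound 2 in one place: 4-fluoro-3,5-dimethylphenyl in place of 4-fluorophenyl on an aromatic carbon. The ring that changes here is the same one varied in all three measured steps. Among the measured compounds shown here, the closest precedent is a 1.1-fold higher number from compound 2 to compound 3 (0.05 log units; within the scatter), which exchanges fluoro for methyl on this ring without leaving the scatter; the exchanges in a 1.9-fold higher number from compound 1 to compound 2 (0.28 log units; within the scatter) and a 2.2-fold higher number from compound 1 to compound 3 (0.33 log units; beyond the scatter) likewise shifted the number only by roughly the width of the scatter. Keeping the fluoro and adding two methyl groups is therefore expected to give, at most, a step of similar size in this assay, with no clear direction. Compound 4 is estimated at 40 nM, between 15 nM and 110 nM. The expected step is a 1.1-fold higher number from compound 2 to compound 4 (0.02 log units; within the scatter).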

Compound 4, half-maximal inhibitory concentration: 32 nM
The estimate for compound 4 lay 1.3-fold (0.10 log units) above the measured number; measured number inside the range.
By their numbers in this assay, from the lowest: compounds 1, 4, 2 and 3 (each within the scatter of the next, the first and the last beyond it).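

In this assay the 4-fluoro-3,5-dimethylphenyl group brings the first ring at this position with more than one substituent, and it keeps the fluoro of compound 2 while adding two methyl groups; the step (a 1.2-fold lower number from compound 2 to compound 4 (0.07 log units; within the scatter)) shows that compound 4 cannot be separated from compound 2 at this position. The other two steps (a 1.3-fold lower number from compound 3 to compound 4 (0.13 log units; within the scatter)) and (a 1.6-fold higher number from compound 1 to compound 4 (0.20 log units; within the scatter)) also stay inside the scatter, so compound 4 cannot be separated from any measured analogue, even though compound 1 and compound 3 lie just beyond the scatter of each other. No measurement shown here explains why the step from compound 2 to compound 4 stays this small.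

On these data alone, all four compounds carry a six-membered aromatic ring of carbon only at this position, with fluoro, methyl or methoxy as its only substituents, so it remains open whether the number would stay in this narrow band with an amine, a carboxylic acid or a longer chain on that ring. The trifluoromethyl group, the second 4-fluorophenyl group and the 6-carboxy-3,5-dihydroxyhexyl group are common to all four compounds, so their contributions cannot be read from this set.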